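The source may report more compounds than this note shows. Statements on the series, on what has been measured and on what is new or still open speak of the compounds shown alone.

In a functional assay on A549 cells (Homo sapiens) for cytotoxicity, read by sulforhodamine B assay, with a stated time of 3 days (a higher number here means that more compound is needed for the effect, a lower number that less compound is needed), compound 3 `CCOc1c(-c2occ(C)c2CO)ccc2c1CCCC2(C)C` gives 22.9 uM. Compound 2 `Cc1coc(-c2ccc3c(c2O)CCCC3(C)C)c1CO` gives 24.5 uM, which is within the scatter of compound 3. Compound 1 `COc1c(-c2occ(C)c2C(=O)O)ccc2c1CCCC2(C)C` gives 53.5 uM, so it needs clearly more compound than compound 3 for the same effect.

Compound 4 `COc1c(-c2occ(C)c2CO)ccc2c1CCCC2(C)C` has not yet been measured. It differs from compound 3 by one small edit, hydrogen in place of methyl on a saturated chain carbon bound to an oxygen on an aromatic ring, which turns ethoxy into methoxy.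

Among the compounds with values here, one measured step bears on this, a change at the same oxygen. Putting ethyl in place of hydrogen there gave a 1.1-fold lower number from compound 2 to compound 3 (0.03 log units; within the scatter). Since that larger change on the oxygen stayed within the scatter, trimming ethyl to methyl is not expected to move the number noticeably. The expected result is a 1.0-fold higher number from compound 3 to compound 4 (0.02 log units; within the scatter), no shift beyond the scatter. Within the data shown here, with only one such step to go on, the range is kept wide. For compound 4, the estimated value is 24 uM, with an expected range of 12 uM to 45 uM.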

Compound 4, concentration for half-maximal effect: 23.3 uM
For compound 4 the middle estimate is 1.0-fold (0.01 log units) above the measured one; the measured number falls inside the stated range.
By their numbers in this assay, from the lowest: compounds 3, 4 and 2 (each within the scatter of the next); then compound 1.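

In this assay, going from ethoxy to methoxy gives a 1.0-fold higher number from compound 3 to compound 4 (0.01 log units; within the scatter) and methyl in place of hydrogen on the oxygen gives a 1.1-fold lower number from compound 2 to compound 4 (0.02 log units; within the scatter), so hydrogen, methyl and ethyl on this oxygen all read alike within the scatter. Compound 4 also gives the first one-place comparison at the aromatic carbon carrying the acid: hydroxymethyl in place of carboxy gives a 2.3-fold lower number from compound 1 to compound 4 (0.36 log units; beyond the scatter), the only step here beyond the scatter, so among these compounds the number shifts with that change and not with the change on the oxygen. Nothing available explains either result.

As far as these compounds go, it stays open whether a longer chain on the oxygen, such as butyl, would still read alike. From the compounds shown here alone, it is also open where an amide or an amine at that aromatic carbon would fall relative to carboxy and hydroxymethyl.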